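The source may report more compounds than this note shows. Statements on the series, on what has been measured and on what is new or still open speak of the compounds shown alone.

Working notes on the amide series. In an ADME assay on Vero cells (Chlorocebus sabaeus) for cytotoxicity, read by MTT assay, with a stated time of 72 h (a higher number here means that more compound is needed for the effect, a lower number that less compound is needed), compound 1 (`Cc1ccccc1C(=O)Nc1nc(-c2ccccn2)cs1`) gives 6300 nM and compound 2 (`O=C(Nc1nc(-c2ccccn2)cs1)c1cccc(Cl)c1`) gives 7000 nM on the shared core. Going by the values given here, the only measured step is a 1.1-fold higher number from compound 1 to compound 2 (0.05 log units; within the scatter) with 3-chlorophenyl in place of 2-methylphenyl on a carbonyl carbon.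

Compound 3 (`O=C(Nc1nc(-c2ccccn2)cs1)c1ccc(Cl)cc1`) has no standing on these numbers, since its entry reads "not determined" (no result reported) and gives no anchor for the next step. Compound 4 (`O=C(Nc1nc(-c2ccccn2)cs1)c1cccnc1Cl`) carries 2-chloropyridin-3-yl in place of 4-chlorophenyl on a carbonyl carbon. Among the compounds with values here, the new ring holds a hetero atom, and no measured step covers such a ring, so the evidence is indirect.

The expectation therefore rests on compound 2 (7000 nM) and on compound 1 (6300 nM). In this assay no shift beyond the scatter from that level is expected, and no direction can be assigned. For compound 4 the estimated value is 7500 nM (expected range 3000 nM to 22000 nM).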

Compound 4, half-maximal effective concentration: 1900 nM
The estimate for compound 4 lay 3.9-fold (0.60 log units) above the measured number, and the stated range ends above it.
By their numbers in this assay, from the lowest: compound 4; then compounds 1 and 2 (each within the scatter of the next).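

In this assay the place on the carbonyl carbon, which showed no shift beyond the scatter between 2-methylphenyl and 3-chlorophenyl, does respond to the ring exchange, with a 3.7-fold lower number from compound 2 to compound 4 (0.57 log units; beyond the scatter) and a 3.3-fold lower number from compound 1 to compound 4 (0.52 log units; beyond the scatter) for 2-chloropyridin-3-yl. Going by these compounds alone, this is the first ring with a hetero atom at this place and the first step beyond the scatter, though the step from compound 3 cannot be read, as that compound has no result. Nothing on hand accounts for the lower number of compound 4.

The steps shown do not separate the effect of the ring nitrogen from that of the changed chlorine-bearing group. On these data alone, how a plain pyridinyl ring without chlorine, an amine or a carboxylic acid would read at this place remains open.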